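Ether chain variation in a TRPM8 agonist series

This account rests on a few compounds, and the source may have more. Where it says the series, first, only, none or still open, it means among the compounds named here.

Measured so far:
Compound 1 `C=CCc1cc(OC)c(OC(C)C(O[C@@H]2C[C@H](C)CC[C@H]2C(C)C)c2ccc(O)c(OC)c2)c(OC)c1`, 28 nM
Compound 2 `C=CCc1cc(OC)c(OC(C)C(OCCCCCCCC)c2ccc(O)c(OC)c2)c(OC)c1`, 86 nM

Compound 2 stands highest of the two numbers in an assay on HEK293 cells for agonist activity at transient receptor potential cation channel subfamily M member 8 (Homo sapiens), read by fluorescence and calcium flux, with a stated time of 5 min (a lower number here means that less compound is needed, a higher number that more compound is needed for the effect), its nearest neighbour being compound 1 with 28 nM. Compound 3 `C=CCc1cc(OC)c(OC(C)C(OCCOCCCC)c2ccc(O)c(OC)c2)c(OC)c1` carries butoxy in place of hexyl on a saturated chain carbon, two bonds along the chain from an oxygen on a saturated carbon. For the measured compounds named here, the only measured step, a 3.1-fold higher number from compound 1 to compound 2 (0.49 log units; beyond the scatter), concerns the same ether substituent, yet that change swapped a ring for a chain, so it bears on compound 3 only loosely. Going by the values given here, no measured pair tests an oxygen inserted into the chain. A small rise beyond the scatter is expected for compound 3, a 1.7-fold higher number from compound 2 to compound 3 (0.24 log units; within the scatter). Compound 3 is therefore estimated at 150 nM, within 60 nM to 450 nM.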

Compound 3, half-maximal effective concentration: 153 nM
For compound 3 the middle estimate is 1.0-fold (0.01 log units) below the measured one; low and high end bracket the measured number.
By their numbers in this assay, from the lowest: compound 1; then compounds 2 and 3 (each within the scatter of the next).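

In this assay, butoxy in place of hexyl, on a saturated chain carbon, two bonds along the chain from an oxygen on a saturated carbon, gives a 1.8-fold higher number from compound 2 to compound 3 (0.25 log units; within the scatter) and so does not separate the chain with the added hydrogen-bond acceptor from the all-carbon chain. Replacing 2-isopropyl-5-methylcyclohexyl with 2-butoxyethyl gives a 5.5-fold higher number from compound 1 to compound 3 (0.74 log units; beyond the scatter) and shows that the gap to the ring-bearing compound 1 remains with an oxygen in the chain. No supporting data explain either step.

Still open, as far as these compounds go, is how a terminal amine, a terminal carboxylic acid or a longer chain containing the same oxygen would read at this position.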